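Adding a chlorine to the pyridine ring of two vinyl sulfones

A few compounds are considered here, and "the series" means these few. Any claim that something is new, unique, unknown or untested is made for them only; others in the source may bear on it.

Measured so far, in an assay on U2OS cells for activation of nuclear factor erythroid 2-related factor 2 (Homo sapiens), read by chemiluminescence, with a stated time of 6 h; on this read-out higher numbers stand for an effect only at larger amounts of compound and lower numbers for an effect already at smaller amounts:
- compound 1 `COc1ccccc1S(=O)(=O)/C=C/c1ccccn1`: 9070 nM
- compound 2 `COc1ccccc1S(=O)(=O)/C=C/c1ncccc1Cl`: 142 nM
- compound 3 `COc1cccc(S(=O)(=O)/C=C/c2cccnc2)c1`: 6290 nM

Compound 1 and compound 3 are built from the same atoms joined differently; the difference between the two cores is not broken down here. Their values in this assay lie within the usual scatter of each other, so nothing can be said about an order between them.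

Within the data shown here, the one counted step in the set is chloro in place of hydrogen on an aromatic carbon, and it is large: a 64-fold lower number from compound 1 to compound 2 (1.81 log units; beyond the scatter). Compound 4 `COc1cccc(S(=O)(=O)/C=C/c2cccnc2Cl)c1` has not yet been measured. Among the measured compounds shown here, it differs from compound 3 by chloro in place of hydrogen on an aromatic carbon, which is the same kind of change as the one from compound 1 to compound 2, but not the same: in compound 2 the chloro sits two atoms from the ring nitrogen, whereas in compound 4 it sits next to the ring nitrogen, in both cases ortho to a large group.

Because the step of a 64-fold lower number from compound 1 to compound 2 (1.81 log units; beyond the scatter) is so large, the same kind of change on compound 3 is expected to lower the number too; since the place is not identical, a smaller step is estimated, a 10-fold lower number from compound 3 to compound 4 (1.02 log units; beyond the scatter). Compound 4 is therefore expected to give about 600 nM in this assay, most likely between 150 nM and 2500 nM.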

Compound 4, half-maximal effective concentration: 348 nM
Compound 4: the middle estimate sits 1.7-fold (0.24 log units) above what was measured; low and high end bracket the measured number.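

In this assay, chloro in place of hydrogen on an aromatic carbon now lowers the number on a second core (an 18-fold lower number from compound 3 to compound 4 (1.26 log units; beyond the scatter)), in the same direction and again by a large step, as it did on the first core (a 64-fold lower number from compound 1 to compound 2 (1.81 log units; beyond the scatter)). So within these two pairs, the direction of the change carries from one core to the other, although two pairs are too few to make a rule for the whole series, and the chloro does not stand in the same place on the two pyridine rings, so the core and the place are changed together and their shares cannot be separated. The size of the step does not carry over unchanged, which means that a step taken from one core gives the direction on the other but not a reliable number: the same change on two cores in this assay, a 64-fold lower number (1.81 log units; beyond the scatter) from compound 1 to compound 2 and an 18-fold lower number (1.26 log units; beyond the scatter) from compound 3 to compound 4, 3.5-fold (0.55 log units) apart, beyond the scatter of two such steps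

The compounds shown carry only hydrogen or chloro at these ring positions, so it stays open whether a bromo, a methyl, a nitrile or an amine there would lower the number as chloro does. On these data alone, it also stays open whether the two steps would draw closer if the chloro stood in the same place on both cores, or if the methoxy group stood in the same place on both.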